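Sodium/hydrogen exchanger series: ethylsulfanyl in place of propyl

The source may report more compounds than this note shows. Statements on the series, on what has been measured and on what is new or still open speak of the compounds shown alone.

Measured compounds, read out in a functional assay for inhibition of sodium/hydrogen exchanger (Oryctolagus cuniculus); on this read-out higher numbers stand for weaker inhibition and lower numbers for stronger inhibition:

Compound 1 `CS(=O)(=O)c1cc(C(=O)N=C(N)N)c(F)cc1F` — 630 nM
Compound 2 `CCCc1cc(C)c(C(=O)N=C(N)N)cc1S(C)(=O)=O` — 5.7 nM
Compound 3 `Cc1ccc(-c2ccc(C(=O)N=C(N)N)cc2S(C)(=O)=O)cc1` — 100 nM

Compound 2 stands lowest of the three numbers in this assay. The nearest of the others is compound 3, whose number lies beyond the scatter above it; compound 1 lies further still, also beyond the scatter. Among the compounds with values here, none of the three measured compounds differ from another in a single place, so no measured single-change step is available in this set, and the three numbers show only that the shared core tolerates a range of substitution patterns with strongly differing outcomes.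

Compound 4 `CCSc1cc(C)c(C(=O)N=C(N)N)cc1S(C)(=O)=O` is the unmeasured follow-up to compound 2. The change is ethylsulfanyl in place of propyl on an aromatic carbon. The group that leaves and the group that enters have the same heavy-atom count and differ only in the exchange of one carbon for a sulfur, which adds one hydrogen-bond acceptor.

Within the data shown here, with no measured step of this kind, the expectation for the step from compound 2 to compound 4 is a change of no more than the scatter in either direction, a 1.4-fold higher number from compound 2 to compound 4 (0.15 log units; within the scatter), expected rather than known. Compound 4 is therefore estimated at 8 nM in this assay, with a range of 3 nM to 25 nM.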

Compound 4, half-maximal inhibitory concentration: 5.9 nM
For compound 4 the middle estimate is 1.4-fold (0.13 log units) above the measured one; low and high end bracket the measured number.
By their numbers in this assay, from the lowest: compounds 2 and 4 (each within the scatter of the next); then compound 3; then compound 1.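

In this assay, within the data shown here, the exchange of propyl for ethylsulfanyl gives the only single-change step in the set, a 1.0-fold higher number from compound 2 to compound 4 (0.01 log units; within the scatter), so at this aromatic carbon, ortho to the methylsulfonyl group and para to a group of 6 heavy atoms, one chain carbon can give way to a sulfur with no change beyond the scatter. The hydrogen-bond acceptor that enters with ethylsulfanyl, absent from propyl, thus comes with no measurable shift in this read-out, at least for this pair, where the methyl group and the methylsulfonyl group stay in place. Nothing measured alongside these numbers bears on why the two groups read alike.

Open, going by these compounds, is whether a longer chain such as butyl, an ethoxy group or an amine on this aromatic carbon would read as propyl and ethylsulfanyl do in this assay. Equally open, on these data alone, is whether the same exchange would read alike if the methyl group on the shared core gave way to a chlorine or a trifluoromethyl group.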